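The compounds below may be only part of what the source reports. "The series", "measured", "known", "first", "only" and "open" are said of these compounds alone.

Working notes on the series. The shared core is kept throughout; the aryl group on it is varied. Compound 1 `COc1ccc(S(=O)(=O)N2CCc3cccc(-c4cccnc4)c32)cc1` gives 95.9 nM in a functional assay on KB cells (Homo sapiens) for inhibition, with a stated time of 72 h; on this read-out higher numbers stand for weaker inhibition and lower numbers for stronger inhibition. Compound 2 `COc1ccc(S(=O)(=O)N2CCc3cccc(-c4ccc(O)cc4)c32)cc1` gives 129 nM in this assay, and compound 3 `COc1ccc(S(=O)(=O)N2CCc3cccc(-c4ccc(F)nc4)c32)cc1` gives 143 nM. Compound 3 thus carries the highest number of the three, yet the step of a 1.1-fold higher number from compound 2 to compound 3 (0.04 log units; within the scatter) is within the scatter and the step of a 1.5-fold higher number from compound 1 to compound 3 (0.17 log units; within the scatter) is also within the scatter, so no order among the three can be claimed.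

Compound 4 `COc1ccc(-c2cccc3c2N(S(=O)(=O)c2ccc(OC)cc2)CC3)cc1` is not yet measured. Its change from compound 3 is 4-methoxyphenyl in place of 6-fluoropyridin-3-yl on an aromatic carbon. Among the measured compounds shown here, two measured steps bear on this exchange of a heteroaryl for a substituted phenyl: a 1.3-fold higher number from compound 1 to compound 2 (0.13 log units; within the scatter) and a 1.1-fold higher number from compound 2 to compound 3 (0.04 log units; within the scatter), both within the scatter. Each swap between a pyridine-type ring and a phenyl-type ring so far has moved the number by less than the scatter, so for compound 4 a step of a 1.2-fold lower number from compound 3 to compound 4 (0.08 log units; within the scatter) is expected, with no movement beyond the scatter in either direction. Compound 4 is therefore estimated at 120 nM in this assay, within a range from 50 nM to 300 nM, the width reflecting the scatter rather than any directional expectation.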

Compound 4, half-maximal inhibitory concentration: 337 nM
Compound 4: middle estimate off by 2.8-fold (0.45 log units), on the low side; the measured number lies above the stated range.
By their numbers in this assay, from the lowest: compounds 1, 2 and 3 (each within the scatter of the next); then compound 4.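

In this assay, this position on an aromatic carbon now shows that the aryl group can matter: the exchange of 6-fluoropyridin-3-yl for 4-methoxyphenyl gives a 2.4-fold higher number from compound 3 to compound 4 (0.37 log units; beyond the scatter), and the exchange of pyridin-3-yl for the same group gives a 3.5-fold higher number from compound 1 to compound 4 (0.55 log units; beyond the scatter). The closest comparison changes only the substituent on the oxygen, with methyl in place of hydrogen, and gives a 2.6-fold higher number from compound 2 to compound 4 (0.42 log units; beyond the scatter), so the aryl groups of compounds 1, 2 and 3 remain within the scatter of one another while an oxygen-bound methyl on the phenyl ring is enough to produce a modest step to a higher number. No supporting data bear on why this methyl group shifts the read-out.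

The compounds shown leave open whether the higher number is specific to methoxy or would also appear with a longer chain on the oxygen, such as ethoxy, or with a methyl group attached directly to the phenyl ring. They also leave open how an amine or a carboxylic acid at this point on the phenyl ring would compare with the hydroxyl of compound 2 and the methoxy of compound 4.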